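The source may report more compounds than this note shows. Statements on the series, on what has been measured and on what is new or still open speak of the compounds shown alone.

Compound 1 `Cc1cccc(Sc2ccnc(-c3ccccn3)n2)c1`: 2300 nM
Compound 2 `Clc1ccc(Nc2ccnc(-c3ccccn3)n2)cc1`: > 10000 nM
Compound 3 `Clc1ccc(Sc2ccnc(-c3ccncc3)n2)cc1`: > 10000 nM

In a functional assay for inhibition of metabotropic glutamate receptor 5 (Homo sapiens), read by FLIPR and calcium flux (a lower number here means a stronger inhibitor, a higher number a weaker inhibitor), compound 1 gives 2300 nM. For compound 2 the result is only a limit, > 10000 nM. For compound 3 the result is likewise a limit, > 10000 nM. For the measured compounds named here, compound 1 thus carries the only definite number among the three; the other two sit at the limit of > 10000 nM in this assay, at which 2 of the 3 values shown sit. Compound 4 `Clc1cccc(Sc2ccnc(-c3ccccn3)n2)c1` has not yet been tested. It differs from compound 1 by chloro in place of methyl on an aromatic carbon. Going by the values given here, no two measured compounds differ in a single place, so no measured step shows how such a swap plays out. A change this small is expected to move the value no further than the usual scatter, in no particular direction. Compound 4 is therefore estimated at 2000 nM in this assay, within 700 nM to 6000 nM. The expected step of a 1.2-fold lower number from compound 1 to compound 4 (0.06 log units; within the scatter) stays inside the scatter.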

Compound 4, half-maximal inhibitory concentration: 620 nM
Compound 4: the middle estimate sits 3.2-fold (0.51 log units) above what was measured; measured number outside the range, below it.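

In this assay, the place on the aromatic carbon meta to a large group responds to a very small edit: chloro in place of methyl gives a 3.7-fold lower number from compound 1 to compound 4 (0.57 log units; beyond the scatter). This first measured step shows that exchanging one heavy atom for another, with no hydrogen-bond donor or acceptor gained or lost, can move the number beyond the scatter. Nothing shown explains why this swap has this effect. From the compounds shown here alone, whether an amine or a methoxy group at this place would lower the number further remains open, as does how chloro would behave elsewhere on that ring.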